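Lengthening the Amine Side Chain of Compound 2

The source may report more compounds than this note shows. Statements on the series, on what has been measured and on what is new or still open speak of the compounds shown alone.

Of the compounds shown here, two sharing one core have been measured. Compound 1 `CN(C)CCNc1nc(-c2ccc(NC(=O)Nc3ccc(Cl)cc3Cl)cc2)nc2ccsc12` gives 1650 nM in a functional assay on NCI-H460 cells (Homo sapiens) for cytotoxicity, read by MTT assay, with a stated time of 72 h; on this read-out higher numbers stand for weaker inhibition and lower numbers for stronger inhibition. Compound 2 `Cc1ccc(NC(=O)Nc2ccc(-c3nc(NCCN(C)C)c4sccc4n3)cc2)cc1` gives 1880 nM in this assay. Going by the values given here, the single known step between them, a 1.1-fold higher number from compound 1 to compound 2 (0.06 log units; within the scatter), comes from a 4-methylphenyl in place of a 2,4-dichlorophenyl on an amide-type nitrogen. Among the compounds with values here, compound 2 is thus one of only two measured compounds, and its number differs from that of compound 1 only within the scatter. Compound 3 `CCN(CC)CCCNc1nc(-c2ccc(NC(=O)Nc3ccc(C)cc3)cc2)nc2ccsc12` is not yet measured. It differs from compound 2 by (diethylamino)methyl in place of dimethylamino on a saturated chain carbon, two bonds along the chain from a nitrogen on an aromatic ring. Within the data shown here, the one known step alters the ring on the amide-type nitrogen, not the amine-bearing chain, so no measured step bears on this change. With nothing pointing in either direction, the expected step of a 1.0-fold higher number from compound 2 to compound 3 (0.00 log units; within the scatter) is none beyond the scatter. Compound 3 is therefore estimated at 1900 nM in this assay, with a range from 800 nM to 4500 nM.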

Compound 3, half-maximal inhibitory concentration: 1240 nM
Estimate against measurement, compound 3: 1.5-fold (0.19 log units) above; low and high end bracket the measured number.
By their numbers in this assay, from the lowest: compounds 3, 1 and 2 (each within the scatter of the next).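

Going by these compounds alone, the amine-bearing chain had not been varied in the earlier compounds, and (3-(diethylamino)propyl)amino in place of (2-(dimethylamino)ethyl)amino gives a 1.5-fold lower number from compound 2 to compound 3 (0.18 log units; within the scatter) in this assay. This first look at the position therefore shows that a longer chain with a larger amine end can be carried without a difference that can be told from the scatter of repeated measurements. Nothing available gives a reason for this result.

Chain length and the groups on the end nitrogen differ together in this one step, so a 3-(dimethylamino)propyl or a 2-(diethylamino)ethyl chain would be needed to tell their contributions apart. From the compounds shown here alone, whether a morpholine or piperazine at the chain end, or a still longer chain, would move the number beyond the scatter also remains open.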